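Ethyl on the pyrazole nitrogen of a kinase inhibitor

The compounds below may be only part of what the source reports. "The series", "measured", "known", "first", "only" and "open" are said of these compounds alone.

Of the compounds shown here, three sharing one core have been measured in an assay on isolated protein for inhibition of Discoidin domain-containing receptor 2 (Homo sapiens), read by ELISA, with a stated time of 60 min; a higher number here means a weaker inhibitor, a lower number a stronger inhibitor. Compound 1 `Cc1ccc(C(=O)Nc2cccc(CN3CCN(C)CC3)c2)cc1-c1ccc2cn[nH]c2c1` gives 75.9 nM. Compound 2 `Cc1ccc(C(=O)Nc2cccc(C(F)(F)F)c2)cc1-c1ccc2c(-c3ccc(CN4CCN(C)CC4)cc3)n[nH]c2c1` gives 6.2 nM. Compound 3 `Cc1ccc(C(=O)Nc2cccc(C(F)(F)F)c2)cc1-c1ccc2c(-c3cn[nH]c3)n[nH]c2c1` gives 55.6 nM, the second highest of the three numbers; the gap to compound 1 lies within the scatter of repeated measurements, while compound 2 sits clearly lower, beyond the scatter.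

Compound 4 `CCn1cc(-c2n[nH]c3cc(-c4cc(C(=O)Nc5cccc(C(F)(F)F)c5)ccc4C)ccc23)cn1` differs from compound 3 in one place: ethyl in place of hydrogen on an aromatic nitrogen. Going by the values given here, no measured pair in this set shows this exact change, so the expectation rests on the small size of the added group alone. The step from compound 3 to compound 4 in this assay is expected to be modest, probably toward a somewhat lower number, and possibly not beyond the scatter, giving a 1.4-fold lower number from compound 3 to compound 4 (0.14 log units; within the scatter). On that basis compound 4 is estimated at 40 nM, with a plausible range from 12 nM to 130 nM.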

Compound 4, half-maximal inhibitory concentration: 2.6 nM
Compound 4: middle estimate off by 15-fold (1.19 log units), on the high side; measured number below the stated range.
By their numbers in this assay, from the lowest: compound 4; then compound 2; then compounds 3 and 1 (each within the scatter of the next).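

In this assay, ethyl in place of hydrogen on the aromatic nitrogen gives a 21-fold lower number from compound 3 to compound 4 (1.33 log units; beyond the scatter), a large step from a change of only 2 heavy atoms. This shows that the hydrogen on this nitrogen of the 1H-pyrazol-4-yl group is not needed for a low number in this pair, and that the position accepts an ethyl group with a strong gain. No supporting measurement is available to explain the size of this step.

With only hydrogen and ethyl shown on this nitrogen, it remains open how the number would respond to a smaller methyl group, a longer propyl chain, or a chain ending in an amine. As far as these compounds go, it also remains open whether ethyl would give a similar step if the rest of the molecule were different.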